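A Third Methoxy Group on a Shared Core

This account rests on a few compounds, and the source may have more. Where it says the series, first, only, none or still open, it means among the compounds named here.

Of the compounds shown here, three have been tested in a functional assay on COLO 205 cells (Homo sapiens) for cytotoxicity, read by sulforhodamine B assay, with a stated time of 48 h, tested at 1 uM; a higher number here means a weaker effect of the compound at the concentration tested, a lower number a stronger effect. Compound 3 `COc1ccc(-c2cc(/C=C/C(=O)c3ccc(N)cc3)[nH]n2)cc1OC` gives 98%. Compound 1 `COc1cc(-c2cc(/C=C/C(=O)c3ccc(N)cc3)[nH]n2)cc(OC)c1OC` differs from compound 3 in one place: methoxy in place of hydrogen on an aromatic carbon. In this assay compound 1 gives 92%, and the step is a number 6 percentage points lower from compound 3 to compound 1 (within the scatter). Compound 2 `COc1ccc(C(=O)/C=C/c2cc(-c3cc(OC)c(OC)c(OC)c3)n[nH]2)cc1OC` carries a different group on the carbonyl carbon; in this assay compound 2 gives 95%, so the step is a number 3 percentage points higher from compound 1 to compound 2 (within the scatter). The difference between the core of compound 2 and the core of compound 3 is not broken down here. All three numbers lie close together.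

Compound 4 `COc1cc(C(=O)/C=C/c2cc(-c3cc(OC)c(OC)c(OC)c3)n[nH]2)cc(OC)c1OC` has not yet been measured. It differs from compound 2 by methoxy in place of hydrogen on an aromatic carbon. Among the compounds with values here, this is the same change as the one from compound 3 to compound 1, and the surroundings of the place are described in the same words. That earlier step was a number 6 percentage points lower from compound 3 to compound 1 (within the scatter) and stayed within the usual scatter. A step of similar small size is therefore expected, a number 3 percentage points lower from compound 2 to compound 4 (within the scatter). For compound 4 in this assay a value of about 92% is expected, most likely between 80% and 100%.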

Compound 4, a percentage reported as activity, at one concentration (the size of the read-out at that concentration, not a potency): 98%
Beside the measured number, compound 4's estimate is 6 percentage points below it; low and high end bracket the measured number.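

In this assay, methoxy in place of hydrogen on an aromatic carbon gives a number 3 percentage points higher from compound 2 to compound 4 (within the scatter), so on this core too, the change has no effect that stands clear of the usual scatter. Set beside the earlier step, the same change does not read differently on the two cores: the same change on two cores in this assay, a number 6 percentage points lower (within the scatter) from compound 3 to compound 1 and a number 3 percentage points higher (within the scatter) from compound 2 to compound 4, 9 percentage points apart, within the scatter of two such steps. This shows that on these two cores the change leaves the read-out at this single concentration within the usual scatter, but it does not show that the change is without any effect, as a small real effect would be hidden in that scatter and a single concentration says nothing about potency.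

The compounds shown leave open whether a different group at that place on the ring, such as a carboxylic acid or a longer chain like ethoxy, would move the number beyond the scatter. They also leave open how the methoxy change would read on a core that gives a clearly stronger effect in this assay.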